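This account rests on a few compounds, and the source may have more. Where it says the series, first, only, none or still open, it means among the compounds named here.

Working notes on the shared core of compound 2 `Cc1cc(N2CCNCC2)nc(SCc2nc3ccccc3[nH]2)n1` and its neighbours. In a functional assay on PC-3 cells (Homo sapiens) for cytotoxicity, read by MTT assay, with a stated time of 72 h (on this read-out higher numbers stand for weaker inhibition and lower numbers for stronger inhibition), compound 2 reaches only the limit > 100000 nM, a boundary of the measurement and not a number. Compound 1 `COc1ccc(Nc2cc(C)nc(SCc3nc4ccccc4[nH]3)n2)cc1` carries a (4-methoxyphenyl)amino group in the same place, and in this assay compound 1 gives 67400 nM. Compound 3 `Cc1cc(Nc2cccc(C(F)(F)F)c2)nc(SCc2nc3ccccc3[nH]2)n1` carries a trifluoromethyl-substituted phenylamino group there; in this assay compound 3 also stops at the limit > 100000 nM. Compound 2 thus stands at the limit of > 100000 nM in this assay, at which 2 of the 3 values shown sit, and compound 1 is the only one of the three that yields a figure.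

The step to compound 4 `Cc1cc(Nc2ccc(F)cc2)nc(SCc2nc3ccccc3[nH]2)n1` is (4-fluorophenyl)amino in place of piperazin-1-yl on an aromatic carbon. Among the compounds with values here, the one measured step touching this position is an at least 1.4-fold higher number from compound 1 to compound 2 (0.17 log units; that floor lies within the scatter), in which a phenylamino group gave way to piperazin-1-yl; it runs the other way from the present change, and its floor lies within the scatter. Compound 3 shows that a phenylamino group need not lift the value off the limit. The expected step is therefore small or none beyond the scatter, leaning toward a lower number; the estimate implies an at least 1.2-fold lower number from compound 2 to compound 4 (0.09 log units; that floor lies within the scatter). For compound 4 the expected value in this assay is 80000 nM, within 40000 nM to 200000 nM, with a fair chance that the result is again a limit.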

Compound 4, half-maximal inhibitory concentration: 56200 nM
Estimate against measurement, compound 4: 1.4-fold (0.15 log units) above; measured number inside the range.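

In this assay, (4-fluorophenyl)amino in place of piperazin-1-yl on this aromatic carbon gives an at least 1.7-fold lower number from compound 2 to compound 4 (0.25 log units; that floor lies within the scatter), so the floor of this step is still no proof of a real change at this position. Among the phenylamino groups that yield a figure, the change of substituent gives a 1.2-fold lower number from compound 1 to compound 4 (0.08 log units; within the scatter), and the two groups cannot be told apart on this read-out. A phenylamino group alone is not enough to yield a figure, and compound 3 goes against that reading, since it stops at a limit of the assay, as compound 2 does: the limit of > 100000 nM in this assay, at which 2 of the 4 values shown sit.

Going by these compounds, it remains open whether any group at this position can give a step beyond the scatter, for instance an unsubstituted phenylamino group, a phenylamino group carrying a carboxylic acid, or a simple amine with a longer chain. The compounds shown also share the methyl group and the thioether link of the core, so what a change at either of those places would do to the number is left unanswered.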